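The source may hold more compounds than are shown below. What is called first, only, known or untested is meant among the compounds shown, and "the series" means these compounds.

Measured so far:
compound 1 `O=C(COCc1ccccc1)N1CCN(c2ccccc2)CC1` with 7100 nM
compound 2 `O=C(COCc1cccnc1)N1CCN(c2ccc(Cl)cc2Cl)CC1` with 1090 nM

Both values come from a functional assay on HEK293 cells for positive allosteric modulation of metabotropic glutamate receptor 5 (Homo sapiens), read by FLIPR and calcium flux; on this read-out lower numbers stand for an effect already at smaller amounts and higher numbers for an effect only at larger amounts of compound. Compound 2 stands lowest of the two numbers; its nearest neighbour is compound 1, whose number is higher by an amount beyond the usual scatter. Within the data shown here, compound 1 and compound 2 differ from each other in more than one place, so their two values show only that compound 2 acts at the smaller concentration.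

The step in question leads from compound 2 to compound 3 `O=C(CSc1ccccc1)N1CCN(c2ccc(Cl)cc2Cl)CC1`, which has not yet been measured in this assay. The change is phenylsulfanyl in place of (pyridin-3-yl)methoxy on a saturated chain carbon bound to a carbonyl carbon. Among the measured compounds shown here, no comparable step between measured compounds is available, so the size of the step rests on the change alone. A modest step is expected from compound 2 to compound 3, of a 1.4-fold lower number from compound 2 to compound 3 (0.13 log units; within the scatter), likely within the scatter. For compound 3 in this assay the estimate is 800 nM, with a range from 200 nM to 3500 nM.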

Compound 3, half-maximal effective concentration: > 25000 nM
Compound 3 ended at the assay's limit (the forecaster's own chance of this, stated with the estimate: 10%); middle value at least 31-fold (1.49 log units) away from the limit.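

In this assay compound 3 gives > 25000 nM, which is a limit of the assay and not a number. Among these compounds, on the shared core, phenylsulfanyl in place of (pyridin-3-yl)methoxy on a saturated chain carbon bound to a carbonyl carbon is a large change, with an at least 22-fold higher number from compound 2 to compound 3 (1.36 log units; beyond the scatter), so the read-out depends strongly on the group at this place, which the earlier compounds, differing in more than one place, could not show. The true size of this step stays unfixed, and it rests on a limit: the limit of > 25000 nM in this assay, at which 1 of the 3 values shown sits.

The change swaps the ring, the linking atom and the chain length together, so the compounds shown leave open which of these carries the loss. Phenoxy or (pyridin-3-yl)sulfanyl at this place would separate these features.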